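A few compounds are considered here, and "the series" means these few. Any claim that something is new, unique, unknown or untested is made for them only; others in the source may bear on it.

Measured so far:
compound 1, `COc1ccc(-c2nnc(-c3nsc4ccccc34)o2)cc1`, 45%
compound 2, `COc1ccc(Nc2nnc(-c3nsc4ccccc34)o2)cc1`, 59%
compound 3, `CCn1c(S)nnc1-c1nsc2ccccc12`, 64%

In a functional assay on the whole organism for inhibition, with Rattus norvegicus as the target, with a stated time of 2 h, at a dose of 100 mg/kg by the intraperitoneal route (a lower number here means less inhibition, a higher number more inhibition at the dose given (going by the name of the read-out)), compound 3 gives 64%, the highest of the three numbers. Compound 2, at 59%, lies within the usual scatter of that figure, so the two cannot be told apart; compound 1, at 45%, sits beyond the scatter and clearly lower. No two of these compounds differ in only one place, so no single step can be read from them.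

Compound 4, `Sc1nnc(-c2nsc3ccccc23)n1-c1ccccc1`, has not been measured. It differs from compound 3 by phenyl in place of ethyl on an aromatic nitrogen. Among the compounds with values here, nothing among the measured compounds shows what exchanging an ethyl for a phenyl on this aromatic nitrogen does, so no firm direction can be drawn. The sulfanyl group and the rest of the core are unchanged. The step from compound 3 to compound 4 in this assay is therefore expected to be small, likely no larger than the scatter, and is estimated as a number 6 percentage points lower from compound 3 to compound 4 (within the scatter). Compound 4 is expected to give about 58%, in a range from 35% to 80%.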

Compound 4, a percentage reported as inhibition, in the whole organism at one dose (the size of the read-out at that dose, not a potency): 81%
Compound 4: middle estimate off by 23 percentage points, on the low side, and the stated range ends below it.
By their numbers in this assay, from the lowest: compound 1; then compounds 2 and 3 (each within the scatter of the next); then compound 4.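

The aromatic nitrogen of the five-membered ring turns out to be a position where the substituent matters: in this assay phenyl in place of ethyl gives a number 17 percentage points higher from compound 3 to compound 4 (beyond the scatter) with the sulfanyl group and the rest of the core unchanged. This is the only single-place change among these compounds, and it shows that a six-membered aromatic ring of carbon only is accepted on this nitrogen and goes with more inhibition at the dose given than ethyl does. Nothing available accounts for the size or direction of this step.

On these data alone, whether a longer chain such as butyl, or a benzyl group, on this nitrogen would go with a similar number remains open. So does what an amine in place of the sulfanyl group would do in this whole-organism read-out.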